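Trifluoromethyl in place of methyl: what two values suggest

The compounds below may be only part of what the source reports. "The series", "measured", "known", "first", "only" and "open" are said of these compounds alone.

Compound 1 `Cc1ccccc1CNC(=O)/C=C/c1ccc(O)c(O)c1`: 20000 nM
Compound 2 `Cc1ccc(CNC(=O)/C=C/c2ccc(O)c(O)c2)cc1`: 3700 nM
Compound 3 `O=C(/C=C/c1ccc(O)c(O)c1)NCc1ccc(C(F)(F)F)cc1`: not yet measured

In a functional assay on B16 cells (Mus musculus) for inhibition (on this read-out higher numbers stand for weaker inhibition and lower numbers for stronger inhibition), compound 2 gives 3700 nM, the lower of the two numbers and so the stronger inhibition of the pair. Compound 3 keeps the shared core of compound 2 and differs from it in one place: trifluoromethyl in place of methyl on an aromatic carbon. The change is trifluoromethyl in place of methyl on an aromatic carbon, para to a large group.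

Within the data shown here, only one measured step bears on this, and it does so indirectly. The step of a 5.4-fold lower number from compound 1 to compound 2 (0.73 log units; beyond the scatter) is modest but beyond the scatter. It changes where the methyl sits on the ring, not which group sits there, whereas compound 3 leaves the position alone and replaces the group. The data hold no measured replacement of methyl, so they give no direction for this change, and no step beyond the scatter is expected in this assay.

The estimated step is a 1.2-fold higher number from compound 2 to compound 3 (0.09 log units; within the scatter). Compound 3 is expected at 4500 nM, with an estimated range of 1800 nM to 12000 nM.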

Compound 3, half-maximal inhibitory concentration: 1600 nM
Compound 3: the middle estimate sits 2.8-fold (0.45 log units) above what was measured; the whole stated range lies above it.
By their numbers in this assay, from the lowest: compound 3; then compound 2; then compound 1.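

In this assay, trifluoromethyl in place of methyl on this aromatic carbon, para to a large group, gives a 2.3-fold lower number from compound 2 to compound 3 (0.36 log units; beyond the scatter), a modest step toward stronger inhibition. Among these compounds, the earlier compounds showed only that moving the methyl changes the number; this is the first measured replacement of the methyl itself, and it shows that the identity of the group at this position also matters in this assay. No accompanying measurement links the step to any particular property of trifluoromethyl, so the data give the direction and size of the change but no explanation for it.

The compounds shown leave open whether chlorine, methoxy or a nitrile on this same aromatic carbon would lower the number further, match trifluoromethyl or raise the number again. They also leave open whether trifluoromethyl would produce a comparable step at the ring position that carries the methyl in compound 1, or whether this step would persist with a longer chain between the amide nitrogen and the ring.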